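A few compounds are considered here, and "the series" means these few. Any claim that something is new, unique, unknown or untested is made for them only; others in the source may bear on it.

Working notes on the series in an ADME assay on BJ cells (Homo sapiens) for cytotoxicity, read by luminescence, with a stated time of 72 h; a higher number here means that more compound is needed for the effect, a lower number that less compound is needed. Compound 1 (`CCOC(=O)c1c(-c2cccc(OC)c2)[nH]c2cc(OC)c(F)cc2c1=O`) gives only a limit, > 21500 nM. Compound 2 (`CCOC(=O)c1c(-c2cccc(Cl)c2)[nH]c2cc(OC)c(F)cc2c1=O`) also gives only a limit, > 21500 nM. Compound 3 (`CCOC(=O)c1c(-c2cccc(Oc3c(C)cccc3C)c2)[nH]c2cc(OC)c(F)cc2c1=O`) likewise stands at a limit and not at a number, > 21500 nM. The whole set so far comes down to the limit of > 21500 nM in this assay, at which 3 of the 3 values shown sit.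

Compound 4 (`CCOC(=O)c1c(-c2cccc(-c3nc(C)c(C)s3)c2)[nH]c2cc(OC)c(F)cc2c1=O`) carries 4,5-dimethyl-1,3-thiazol-2-yl in place of 2,6-dimethylphenoxy on an aromatic carbon.

The bearing steps change the same aromatic ring, and none has a readable size: a step that the two limits leave unreadable from compound 1 to compound 2, a step that the two limits leave unreadable from compound 1 to compound 3 and a step that the two limits leave unreadable from compound 2 to compound 3. No group at this place has yet produced a measured number, so there is no measured size to carry over to the new group. The expectation therefore rests on these steps and is for no change beyond the scatter, with a further limit the likeliest report.

The expected step is a step that the limit leaves unreadable from compound 3 to compound 4. For compound 4 the estimated value is 25000 nM, within an expected range of 12000 nM to 45000 nM.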

Compound 4, half-maximal effective concentration: > 21500 nM
Compound 4 was reported as a limit; the forecaster's own chance of this, stated with the estimate: 85%; the middle value lies beyond the limit too.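

Compound 4 stands at a limit in this assay, as do compound 1, compound 2 and compound 3, so no step among these compounds can be read: the limit of > 21500 nM in this assay, at which 4 of the 4 values shown sit. The compounds shown leave open whether any group at this place gives a measurable half-maximal effective concentration.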